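Amide-end variation in the dihydroxy acid series

The source may report more compounds than this note shows. Statements on the series, on what has been measured and on what is new or still open speak of the compounds shown alone.

Compound 3 `Cc1cccc(CNC(=O)c2nn(-c3ccc(F)cc3)c(OC[C@@H](O)C[C@@H](O)CC(=O)O)c2C(C)C)c1` holds the lowest number of the three measured in an assay on microsomes from liver for inhibition of 3-hydroxy-3-methylglutaryl-coenzyme A reductase (Rattus norvegicus) (on this read-out lower numbers stand for stronger inhibition and higher numbers for weaker inhibition), at 4.9 nM. Compound 2 `CC(C)c1c(C(=O)N(C)Cc2ccccc2)nn(-c2ccc(F)cc2)c1OC[C@@H](O)C[C@@H](O)CC(=O)O` gives 5.2 nM in this assay; the step of a 1.1-fold lower number from compound 2 to compound 3 (0.03 log units; within the scatter) lies within the scatter, so the two cannot be ordered. Compound 1 `CCN(Cc1ccccc1)C(=O)c1nn(-c2ccc(F)cc2)c(OC[C@@H](O)C[C@@H](O)CC(=O)O)c1C(C)C` gives 14 nM in this assay, and the steps of a 2.9-fold lower number from compound 1 to compound 3 (0.46 log units; beyond the scatter) and a 2.7-fold lower number from compound 1 to compound 2 (0.43 log units; beyond the scatter) are modest. Compound 4 `Cc1ccccc1CNC(=O)c1nn(-c2ccc(F)cc2)c(OC[C@@H](O)C[C@@H](O)CC(=O)O)c1C(C)C` differs from compound 3 by 2-methylphenyl in place of 3-methylphenyl on a saturated chain carbon bound to an amide-type nitrogen. Within the data shown here, no measured step touches the placement of the methyl on that ring; every measured step concerns the substituent on the amide nitrogen, where change was modest or within the scatter. The expected step of a 1.4-fold higher number from compound 3 to compound 4 (0.15 log units; within the scatter) is therefore none beyond the scatter. Compound 4 is estimated at 7 nM in this assay, with a range from 3 nM to 20 nM.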

Compound 4, half-maximal inhibitory concentration: 17 nM
Compound 4: middle estimate off by 2.4-fold (0.39 log units), on the low side, and the stated range covers the measured number.
By their numbers in this assay, from the lowest: compounds 3 and 2 (each within the scatter of the next); then compounds 1 and 4 (each within the scatter of the next).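

In this assay, 2-methylphenyl in place of 3-methylphenyl gives a 3.5-fold higher number from compound 3 to compound 4 (0.54 log units; beyond the scatter), so with the same atoms, the placement of the ring methyl alone shifts the read-out. The (2-methylbenzyl)amino amide also separates from the benzyl(methyl)amino amide, with a 3.3-fold higher number from compound 2 to compound 4 (0.51 log units; beyond the scatter), whereas a 1.2-fold higher number from compound 1 to compound 4 (0.08 log units; within the scatter) leaves it level with the benzyl(ethyl)amino amide. Nothing measured here accounts for these steps.

Going by these compounds, whether (4-methylbenzyl)amino or (2-methoxybenzyl)amino on the same carbonyl carbon would follow compound 3 or compound 4 stays open. On these data alone, the unsubstituted benzylamino amide also remains open as a reference for both methyl placements.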